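This account rests on a few compounds, and the source may have more. Where it says the series, first, only, none or still open, it means among the compounds named here.

Among the measured compounds shown here, in a functional assay on HaCaT cells (Homo sapiens), read by fluorescence and BrdU incorporation, with a stated time of 48 h, tested at 25 uM (a lower number here means a stronger effect, a higher number a weaker effect of the compound at the concentration tested), compound 2 `COc1cc(OC)c(C(=O)/C=C/c2ccccc2)c(OC)c1` gives 0.1%, the second highest of the three numbers measured so far. Its nearest neighbour is compound 1 `COc1cc(OC)c(C(=O)/C=C/c2ccccc2SC)c(OC)c1`, which carries a methylsulfanyl group on an aromatic carbon of the phenyl ring and gives 0% in this assay. The furthest is compound 3 `COc1cc(O)c(C(=O)/C=C/c2ccccc2OC)c(OC)c1`, which differs from compound 2 in more than one place. In this assay compound 3 gives 29%. For the measured compounds named here, the only single-point step among the measured compounds, a number 0.1 percentage points higher from compound 1 to compound 2 (within the scatter), exchanges a group for hydrogen on an aromatic carbon and leaves the read-out where it was.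

Compound 4 `COc1cc(OC)c(C(=O)/C=C/c2ccc(Br)cc2)c(OC)c1` differs from compound 2 by bromo in place of hydrogen on an aromatic carbon, on the phenyl ring, para to a large group. Going by the values given here, the one measured step that bears on such a swap on this ring, a number 0.1 percentage points higher from compound 1 to compound 2 (within the scatter), stayed within the scatter, so the expected step of a number 1.9 percentage points higher from compound 2 to compound 4 (within the scatter) in this assay is likewise one that stays within the scatter, with no direction favoured. The estimate for compound 4 in this assay is therefore 2%, with a range from 0% to 15%.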

Compound 4, a percentage reported as activity, at one concentration (the size of the read-out at that concentration, not a potency): 0.3%
Beside the measured number, compound 4's estimate is 1.7 percentage points above it; measured number inside the range.
By their numbers in this assay, from the lowest: compounds 1, 2 and 4 (each within the scatter of the next); then compound 3.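

Compound 4 is the first of these compounds to carry a group para to a large group on the phenyl ring, and in this assay the step of a number 0.2 percentage points higher from compound 2 to compound 4 (within the scatter) shows that bromo can take the place of hydrogen there without moving the read-out beyond the usual scatter. Placing a single bromine atom at this position therefore gives the same picture as the earlier exchange of methylsulfanyl for hydrogen, and the larger exchange of one substituted ring for another, a number 0.3 percentage points higher from compound 1 to compound 4 (within the scatter), also stays within the scatter, so the phenyl ring has now tolerated three different substitution states in this assay without a measurable difference. Nothing measured on these compounds gives a reason for this result.

The compounds shown leave open whether this tolerance extends beyond bromo and methylsulfanyl, for example to an amine or a carboxylic acid at the same position of the phenyl ring. They also leave open which of the several differences between compound 2 and compound 3 accounts for the much higher number of compound 3, since no single-place step connects that compound to the others.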